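This account rests on a few compounds, and the source may have more. Where it says the series, first, only, none or still open, it means among the compounds named here.

In an ADME assay on HUVEC cells (Homo sapiens) for inhibition, read by CCK-8 assay, with a stated time of 24 h, in the presence of a further agent that is not named here (on this read-out higher numbers stand for weaker inhibition and lower numbers for stronger inhibition), compound 1 `O=C1Nc2ccc(F)cc2C1=Cc1ccc(-c2cn(-c3ccccc3)nn2)cc1` gives 13700 nM. Compound 2 `N#Cc1ccccc1-n1cc(-c2ccc(C=C3C(=O)Nc4ccc(F)cc43)cc2)nn1` stands only at a limit, > 20000 nM. Compound 3 `N#Cc1ccc(-n2cc(-c3ccc(C=C4C(=O)Nc5ccc(F)cc54)cc3)nn2)cc1` differs from compound 2 in one place: 4-cyanophenyl in place of 2-cyanophenyl on an aromatic nitrogen. Going by the values given here, the only measured step that bears on this is an at least 1.4-fold higher number from compound 1 to compound 2 (0.16 log units; that floor lies within the scatter), and it gives no firm size for a nitrile on that phenyl ring. No change beyond the scatter is therefore expected in this assay, and the expected step is an at least 1.1-fold lower number from compound 2 to compound 3 (0.04 log units; that floor lies within the scatter). For compound 3 the estimate is 18000 nM, expected to lie between 8000 nM and 40000 nM.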

Compound 3, half-maximal inhibitory concentration: > 20000 nM
Compound 3 ended at the assay's limit; the forecaster's own chance of this, stated with the estimate: 45%; at least 1.1-fold (0.04 log units) between middle value and limit.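

Moving the nitrile from 2-cyanophenyl to 4-cyanophenyl on the aromatic nitrogen gives a second compound at the limit in this assay, so reaching that limit is not confined to one placing of the nitrile. With 4-cyanophenyl the step is an at least 1.4-fold higher number from compound 1 to compound 3 (0.16 log units; that floor lies within the scatter). The step between compound 2 and compound 3 cannot be read because both values are limits: the limit of > 20000 nM in this assay, at which 2 of the 3 values shown sit.

The compounds shown leave open whether any group on this phenyl ring shifts the number beyond the scatter. They also leave open whether an amine or a carboxylic acid there would give a value inside the assay's range.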